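This account rests on a few compounds, and the source may have more. Where it says the series, first, only, none or still open, it means among the compounds named here.

Measured compounds:
Compound 1, `C[C@H](NC(=O)C(c1cccnc1)N(C(=O)c1ccco1)c1ccc(-c2ccccc2)cc1)c1ccccc1`, in a toxicity assay on Vero C1008 cells (Chlorocebus sabaeus) for cytotoxicity, read by neutral red uptake, with a stated time of 5 days (on this read-out higher numbers stand for lower toxicity in this test and lower numbers for higher toxicity in this test), gives > 200000 nM, which is a limit of the assay and not a number.
Compound 2, `C[C@H](NC(=O)C(c1cccnc1)N(C(=O)c1c[nH]cn1)c1ccc(-c2ccccc2)cc1)c1ccccc1`, in this assay gives 129000 nM.

For the measured compounds named here, compound 2 thus holds the only real number in this assay among the two measured compounds; the other entry is a limit. Going by the values given here, the step of an at least 1.5-fold lower number from compound 1 to compound 2 (0.19 log units; that floor lies within the scatter) is the sole measured change at the carbonyl carbon, and its floor lies within the scatter, so it shows no clear movement in either direction. The limit of > 200000 nM in this assay, at which 1 of the 2 values shown sits, marks where the value for compound 1 sits.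

Compound 3, `C[C@H](NC(=O)C(c1cccnc1)N(C(=O)c1ccno1)c1ccc(-c2ccccc2)cc1)c1ccccc1`, differs from compound 2 by 1,2-oxazol-5-yl in place of 1H-imidazol-4-yl on a carbonyl carbon. Among the compounds with values here, no measured step covers this exchange directly; the only comparison at the same place is the small step just described. For compound 3 the expected step is therefore a 1.4-fold higher number from compound 2 to compound 3 (0.14 log units; within the scatter), a modest move toward a higher number, with a real chance that only a limit is reported, as for compound 1 at the limit of > 200000 nM in this assay, at which 1 of the 2 values shown sits. The estimate for compound 3 in this assay is 180000 nM, ranging from 90000 nM to 300000 nM.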

Compound 3, half-maximal cytotoxic concentration: > 200000 nM
Compound 3: no number, only a limit; the forecaster's own chance of this, stated with the estimate: 40%; at least 1.1-fold (0.04 log units) between middle value and limit.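

In this assay compound 3 gives > 200000 nM, which is a limit of the assay and not a number, and 1,2-oxazol-5-yl on the carbonyl carbon thereby joins furan-2-yl at the same limit: the limit of > 200000 nM in this assay, at which 2 of the 3 values shown sit.

The exchange of 1H-imidazol-4-yl for 1,2-oxazol-5-yl gives an at least 1.5-fold higher number from compound 2 to compound 3 (0.19 log units; that floor lies within the scatter), so this second readable step at the position, like the first, shows no clear movement in either direction. For the compounds shown here, the step between compound 1 and compound 3 cannot be read, and compound 2, with 1H-imidazol-4-yl, remains the only compound of the three with a real number in this assay.

The limits leave open how far the true values of compound 1 and compound 3 lie from that of compound 2, and whether any of the three differs from the others by more than the scatter. The compounds shown cover only five-membered aromatic rings on this carbonyl carbon, so they do not tell how a carboxylic acid, an amine or a longer alkyl chain at the same place would read in this assay.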